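From 4-methoxyphenyl to 4-bromophenyl in growth inhibition

The compounds below may be only part of what the source reports. "The series", "measured", "known", "first", "only" and "open" are said of these compounds alone.

compound 1 `C=CCc1ccc(OCc2cn(-c3ccc(OC)cc3)nn2)c(O)c1` gives 62.3%
compound 2 `C=CCc1cc(O)c(O)c(CN2CCC(CO)CC2)c1` gives 34.1%

In a functional assay on MIA PaCa-2 cells (Homo sapiens) for inhibition, read by MTT assay, with a stated time of 72 h, tested at 30 uM (on this read-out higher numbers stand for more inhibition of growth at the one concentration tested and lower numbers for less inhibition of growth), compound 1 stands highest of the two measured compounds, and the gap down to compound 2 lies beyond the scatter. Compound 3 `C=CCc1ccc(OCc2cn(-c3ccc(Br)cc3)nn2)c(O)c1` departs from compound 1 in one place. The change is bromo in place of methoxy on an aromatic carbon (bromo in place of methoxy on an aromatic carbon, para to a large group). Within the data shown here, no measured pair shows this change, so no step beyond the scatter is expected in this assay in either direction. The expected step is a number 2.7 percentage points higher from compound 1 to compound 3 (within the scatter) and it would leave the value close to where it stands. For compound 3 the estimated value is 65% (expected range 45% to 82%).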

Compound 3, percent growth inhibition at one concentration: 43.3%
For compound 3 the middle estimate is 21.7 percentage points above the measured one; measured number below the stated range.
By their numbers in this assay, from the lowest: compounds 2 and 3 (each within the scatter of the next); then compound 1.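

In this assay, among these compounds, bromo in place of methoxy on an aromatic carbon, para to a large group, gives the first step that can be read in one place: a number 19 percentage points lower from compound 1 to compound 3 (beyond the scatter), so what sits at this position does affect growth inhibition. The two groups are all that this step compares, and nothing here bears on the reason for it.

From the compounds shown here alone, whether an amine or a carboxylic acid at this position would stay close to compound 1 or to compound 3 remains open. So does whether the same change would give a similar step elsewhere on the shared core.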